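Swapping methyl for chloro on a weak serotonin receptor ligand

The compounds below may be only part of what the source reports. "The series", "measured", "known", "first", "only" and "open" are said of these compounds alone.

Compound 1, `Cc1cccc(-c2n[nH]cc2N2CCCNCC2)c1`: > 10000 nM
Compound 2, `Cc1ccc(-c2n[nH]cc2N2CCCNCC2)cc1`: > 10000 nM

Both measured compounds share one core and differ only in where a methyl group sits on the outer ring. In an assay on isolated protein for binding affinity to 5-hydroxytryptamine receptor 4 (Homo sapiens) (on this read-out lower numbers stand for stronger inhibition and higher numbers for weaker inhibition), compound 1 gives > 10000 nM, which is a limit of the assay rather than a number. In this assay compound 2 gives > 10000 nM, again only a limit. Compound 2 thus stands at the limit of > 10000 nM in this assay, at which 2 of the 2 values shown sit, so nothing on the numbers shown separates it from compound 1. Compound 3, `Clc1ccc(-c2n[nH]cc2N2CCCNCC2)cc1`, has not yet been measured; it differs from compound 2 by chloro in place of methyl on an aromatic carbon. Among the compounds with values here, no measured pair shows what such a change does here, so there is no basis to expect a move beyond the usual scatter in either direction. The step of a number no higher from compound 2 to compound 3 (the limit leaves the size open) is therefore expected to be small or none. Compound 3 is estimated at 10000 nM, within 3000 nM to 30000 nM, with a good chance that only a limit is reported again.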

Compound 3, inhibition constant: > 10000 nM
Compound 3 ended at the assay's limit; the forecaster's own chance of this, stated with the estimate: 70%; the middle value sits exactly at the limit.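

In this assay compound 3 gives > 10000 nM, which is a limit and not a number. Compound 2 also sits at a limit, so no step from compound 2 to compound 3 can be read: the limit of > 10000 nM in this assay, at which 3 of the 3 values shown sit.

The compounds shown leave open what chloro in place of methyl does to binding.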